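Trimming the Propargyl Thioether to a Methyl Thioether

The compounds below may be only part of what the source reports. "The series", "measured", "known", "first", "only" and "open" are said of these compounds alone.

Measured compounds:
compound 1, `CCc1nnc(SC)n1N1C(=O)c2ccccc2C1=O`, gives > 200000 nM
compound 2, `C#CCSc1nnc(CCC)n1N1C(=O)c2ccccc2C1=O`, gives > 200000 nM

Both of these values are limits of the assay rather than numbers. In a functional assay on A549 cells (Homo sapiens) for cytotoxicity, read by MTT assay, with a stated time of 48 h (on this read-out higher numbers stand for weaker inhibition and lower numbers for stronger inhibition), compound 2 stands at the limit of > 200000 nM in this assay, at which 2 of the 2 values shown sit. Compound 1 stands at the same limit, so no ordering between the two can be drawn from these results.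

Compound 3, `CCCc1nnc(SC)n1N1C(=O)c2ccccc2C1=O`, differs from compound 2 by hydrogen in place of ethynyl on a saturated chain carbon bound to a sulfur. Among the compounds with values here, no step between measured compounds is available for this change, and the ethyl-to-propyl pair of compound 1 and compound 2 shows only two limits. Compound 1 already carries the methylsulfanyl group and reaches only the limit, so the change is not expected to move the value beyond the scatter. The step that the limit leaves unreadable from compound 2 to compound 3 is therefore estimated to be essentially flat. Compound 3 is expected to give about 250000 nM in this assay, between 120000 nM and 500000 nM, most likely reported again as a limit.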

Compound 3, half-maximal inhibitory concentration: > 200000 nM
Compound 3: no number, only a limit; the forecaster's own chance of this, stated with the estimate: 85%; the middle value lies beyond the limit too.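

Compound 3 gives > 200000 nM in this assay, a limit and not a number, and its steps from compound 1 and compound 2 cannot be read. The compounds shown leave open whether exchanging propargylsulfanyl for methylsulfanyl, or ethyl for propyl, changes the value at all.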